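This account rests on a few compounds, and the source may have more. Where it says the series, first, only, none or still open, it means among the compounds named here.

In a functional assay on PC-3 cells (Homo sapiens) for antiproliferative activity, read by MTT assay, with a stated time of 24 h (a lower number here means a stronger inhibitor, a higher number a weaker inhibitor), three compounds sharing one core differ only in the group on an amide-type nitrogen. Compound 1 `CCn1c(C(=O)N[C@@H](C)C(=O)OC)ccc1C(CC)(CC)c1ccc(OCS(=O)(=O)c2ccccc2)c(C)c1` gives > 50000 nM as its reading, which is a limit of the assay and not a number. Compound 2 `CCn1c(C(=O)NC(C)(C)CO)ccc1C(CC)(CC)c1ccc(OCS(=O)(=O)c2ccccc2)c(C)c1` gives 9850 nM as its value. Compound 3 `CCn1c(C(=O)N[C@H](CO)C(C)C)ccc1C(CC)(CC)c1ccc(OCS(=O)(=O)c2ccccc2)c(C)c1` gives 7300 nM as its value and stands level with compound 2, the only other numeric result, with a 1.3-fold lower number from compound 2 to compound 3 (0.13 log units; within the scatter) as the step between them. Compound 4 `CCn1c(C(=O)NCCCO)ccc1C(CC)(CC)c1ccc(OCS(=O)(=O)c2ccccc2)c(C)c1` carries 3-hydroxypropyl in place of 1-(hydroxymethyl)-2-methylpropyl on the same nitrogen, a change counted as 3-hydroxypropyl in place of 1-(hydroxymethyl)-2-methylpropyl on an amide-type nitrogen here. Two measured steps start from the limit of compound 1, namely an at least 5.0-fold lower number from compound 1 to compound 2 (0.70 log units; beyond the scatter) and an at least 6.8-fold lower number from compound 1 to compound 3 (0.83 log units; beyond the scatter) and both remove 1-(methoxycarbonyl)ethyl, a group that neither compound 3 nor compound 4 carries. They therefore bear only loosely on this change. The closer guide is the exchange of one hydroxymethyl-bearing group for another in compound 3, with a 1.3-fold lower number from compound 2 to compound 3 (0.13 log units; within the scatter) as its size, so no step beyond the scatter is expected in this assay here. The expected step is a 1.2-fold higher number from compound 3 to compound 4 (0.09 log units; within the scatter) on this estimate. Compound 4 is estimated at 9000 nM with an expected range from 3500 nM to 30000 nM in this test.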

Compound 4, half-maximal inhibitory concentration: 11300 nM
Compound 4: middle estimate off by 1.3-fold (0.10 log units), on the low side; measured number inside the range.
By their numbers in this assay, from the lowest: compounds 3, 2 and 4 (each within the scatter of the next). At a limit, above all of these: compound 1.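

In this assay, the unbranched 3-hydroxypropyl group, which has no defined stereocentre, cannot be told apart from either branched group on the amide-type nitrogen: there is a 1.5-fold higher number from compound 3 to compound 4 (0.19 log units; within the scatter) and a 1.1-fold higher number from compound 2 to compound 4 (0.06 log units; within the scatter). At this position, then, neither the branching nor the stereocentre of compounds 2 and 3 is needed to give a reading at this level, and the alcohol-bearing side chains shown so far form a single group within the scatter. The straight chain also stays clear of the methyl ester of compound 1, with an at least 4.4-fold lower number from compound 1 to compound 4 (0.64 log units; beyond the scatter), although the size of that step is only a bound, as compound 1 has a limit of the assay and not a number: the limit of > 50000 nM in this assay, at which 1 of the 4 values shown sits.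

The compounds shown leave open whether the hydroxyl itself matters, since every compound with a numeric value carries one, and a plain propyl group, an amine or a carboxylic acid at the end of the chain would test this. From the compounds shown here alone, it also remains open how a longer chain ending in hydroxyl would read in this assay.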